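A few compounds are considered here, and "the series" means these few. Any claim that something is new, unique, unknown or untested is made for them only; others in the source may bear on it.

Measured so far in an ADME assay on HeLa Rh cells (Homo sapiens) for cytotoxicity, read by microscopy; a lower number here means that less compound is tolerated, a higher number that more compound is tolerated:
- compound 1 `COc1cc(CC(O)c2ccc(-c3ccc([N+](=O)[O-])cc3)cc2)c([N+](=O)[O-])cc1OC` gives 21000 nM
- compound 2 `COc1cc(CC(O)c2ccc(-c3ccc(C)cc3)cc2)c([N+](=O)[O-])cc1OC` gives 4700 nM
- compound 3 `COc1cc(CC(O)c2ccc(-c3cccc(F)c3)cc2)c([N+](=O)[O-])cc1OC` gives 7400 nM

Compound 2 stands at the lowest number of the three in this assay; compound 3 sits nearest to it, with a gap that is within the scatter, while compound 1 lies furthest away, beyond the scatter. The step from compound 2 to compound 4 `COc1cc(CC(O)c2ccc(-c3cccc([N+](=O)[O-])c3)cc2)c([N+](=O)[O-])cc1OC` is 3-nitrophenyl in place of 4-methylphenyl on an aromatic carbon. Among the measured compounds shown here, two measured steps bear on it. The closest comparison is a 4.5-fold lower number from compound 1 to compound 2 (0.65 log units; beyond the scatter), which shows that exchanging a nitro for a methyl on this ring moved the number by a modest but clear amount. The step of a 1.6-fold higher number from compound 2 to compound 3 (0.20 log units; within the scatter) stayed within the scatter, and a 2.8-fold lower number from compound 1 to compound 3 (0.45 log units; beyond the scatter) was modest. Since compound 4 brings a nitro back onto this ring, though at a different position than in compound 1, the number for compound 4 is expected to rise toward that of compound 1, by an amount estimated as a 2.6-fold higher number from compound 2 to compound 4 (0.41 log units; beyond the scatter). Compound 4 is therefore estimated at 12000 nM, within a range of 5000 nM to 30000 nM.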

Compound 4, half-maximal cytotoxic concentration: 5500 nM
Estimate against measurement, compound 4: 2.2-fold (0.34 log units) above; low and high end bracket the measured number.
By their numbers in this assay, from the lowest: compounds 2, 4 and 3 (each within the scatter of the next); then compound 1.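

In this assay, the step from the 4-nitrophenyl to the 3-nitrophenyl group gives a 3.8-fold lower number from compound 1 to compound 4 (0.58 log units; beyond the scatter), so a nitro on this ring does not by itself bring the number to that of compound 1. The remaining changes give a 1.2-fold higher number from compound 2 to compound 4 (0.07 log units; within the scatter) and a 1.3-fold lower number from compound 3 to compound 4 (0.13 log units; within the scatter), both within the scatter, so among compound 2, compound 3 and compound 4 this assay does not separate the 4-methylphenyl, 3-fluorophenyl and 3-nitrophenyl groups, and only compound 1 stands apart. Nothing at hand explains why the 4-nitrophenyl group differs from the 3-nitrophenyl group.

The compounds shown leave open whether the number of compound 1 is specific to its nitro or would also appear with a carboxylic acid or an amine in that group's place. They also leave open how a longer chain in place of this ring would read.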